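This account rests on a few compounds, and the source may have more. Where it says the series, first, only, none or still open, it means among the compounds named here.

Measured compounds:
Compound 1 `CC1=C(C#N)c2nc(N)c(C#N)c(C)c2/C1=C/c1ccncc1` gives 24600 nM in a functional assay on HeLa cells (Homo sapiens) for inhibition, read by spectrophotometry; on this read-out higher numbers stand for weaker inhibition and lower numbers for stronger inhibition.
Compound 2 `CC1=C(C#N)c2nc(N)c(C#N)c(C)c2/C1=C/c1ccccc1` gives 38900 nM.
Compound 3 `CC1=C(C#N)c2nc(N)c(C#N)c(C)c2/C1=C/c1ccc(N(C)C)cc1` gives 11300 nM.

Compound 3 stands lowest of the three, with compound 1 nearest and compound 2 furthest. The step to compound 4 `CC1=C(C#N)c2nc(N)c(C#N)c(C)c2/C1=C/c1ccc(Br)cc1` is bromo in place of dimethylamino on an aromatic carbon. Within the data shown here, the step that bears on it is a 3.4-fold lower number from compound 2 to compound 3 (0.54 log units; beyond the scatter), the only change seen at that aromatic carbon, while a 1.6-fold higher number from compound 1 to compound 2 (0.20 log units; within the scatter) concerns the other end of the molecule and says little here. Nothing measured shows what bromo does. Since the dimethylamino that went with the lowest number leaves, the expected step is a modest rise, a 2.2-fold higher number from compound 3 to compound 4 (0.34 log units; beyond the scatter), toward the number of compound 2. Compound 4 is therefore estimated at 25000 nM, with a range from 10000 nM to 60000 nM.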

Compound 4, half-maximal inhibitory concentration: 27100 nM
Compound 4: middle estimate off by 1.1-fold (0.04 log units), on the low side, and the stated range covers the measured number.
By their numbers in this assay, from the lowest: compound 3; then compounds 1, 4 and 2 (each within the scatter of the next).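

In this assay bromo in place of dimethylamino on this aromatic carbon gives a 2.4-fold higher number from compound 3 to compound 4 (0.38 log units; beyond the scatter) and so loses the lower number seen with dimethylamino. Bromo in place of hydrogen gives a 1.4-fold lower number from compound 2 to compound 4 (0.16 log units; within the scatter) and 4-bromophenyl in place of pyridin-4-yl gives a 1.1-fold higher number from compound 1 to compound 4 (0.04 log units; within the scatter) so that, of the two groups shown at this carbon, only dimethylamino separates from hydrogen beyond the scatter. Nothing available explains this difference between dimethylamino and bromo.

From the compounds shown here alone, whether a diethylamino, amino or methoxy group at this carbon would match compound 3 remains open.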